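Extending Compound 3 at Its Aromatic Oxygen

The source may report more compounds than this note shows. Statements on the series, on what has been measured and on what is new or still open speak of the compounds shown alone.

Compound 3 `COc1ccc(N(C)c2ccnc(Cl)n2)cc1O` shows the lowest of the three numbers recorded in a functional assay on MDA-MB-231 cells (Homo sapiens) for antiproliferative activity, read by MTT assay, with a stated time of 48 h; on this read-out lower numbers stand for stronger inhibition and higher numbers for weaker inhibition: compound 3 gives 833 nM. Compound 1 `COc1ccc(N(C)c2ccnc(Cl)n2)cc1Cl` gives 1380 nM, and the gap a 1.7-fold lower number from compound 1 to compound 3 (0.22 log units; within the scatter) falls within the scatter, so the two cannot be ranked. Compound 2 `COc1ccc(N(C)c2ccnc(Cl)n2)cc1[N+](=O)[O-]` gives 8120 nM; here the gap a 9.7-fold lower number from compound 2 to compound 3 (0.99 log units; beyond the scatter) lies beyond the scatter, as does a 5.9-fold higher number from compound 1 to compound 2 (0.77 log units; beyond the scatter).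

Compound 4 `COc1ccc(N(C)c2ccnc(Cl)n2)cc1OCCCC[Se]C#N` differs from compound 3 in one place: a group of 7 heavy atoms (5 carbon, 1 nitrogen, 1 selenium; no ring) in place of a hydrogen atom, on an oxygen on an aromatic ring. Among the measured compounds shown here, none of the measured steps touches this oxygen; each swaps a small group on an aromatic carbon, and their sizes ran from within the scatter (a 1.7-fold lower number from compound 1 to compound 3 (0.22 log units; within the scatter)) to modest (a 9.7-fold lower number from compound 2 to compound 3 (0.99 log units; beyond the scatter)). For the measured compounds named here, no measured step therefore bears directly on adding a group of this size at the aromatic oxygen, and the expectation rests on that silence. The estimated step is a 1.2-fold higher number from compound 3 to compound 4 (0.08 log units; within the scatter), with a wide range to reflect the lack of a guiding precedent. Compound 4 is expected at 1000 nM, within a range from 250 nM to 4000 nM.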

Compound 4, half-maximal inhibitory concentration: > 10000 nM
Compound 4 ended at the assay's limit; the forecaster's own chance of this, stated with the estimate: 5%; middle value at least 10-fold (1.00 log units) from the limit.
By their numbers in this assay, from the lowest: compounds 3 and 1 (each within the scatter of the next); then compound 2. At a limit, above all of these: compound 4.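

The value of compound 4 is a limit of the assay and not a number: the limit of > 10000 nM in this assay, at which 1 of the 4 values shown sits.

Even so, the oxygen of compound 3 proves sensitive to extension, which the earlier swaps on the aromatic carbon could not show: a group of 7 heavy atoms (5 carbon, 1 nitrogen, 1 selenium; no ring) in place of a hydrogen atom, on an oxygen on an aromatic ring, gives a large step, an at least 12-fold higher number from compound 3 to compound 4 (1.07 log units; beyond the scatter). Measured against the chloro compound, the change gives an at least 7.2-fold higher number from compound 1 to compound 4 (0.86 log units; beyond the scatter), while the step of an at least 1.2-fold higher number from compound 2 to compound 4 (0.09 log units; that floor lies within the scatter) cannot be read.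

The compounds shown do not separate the effect of the chain at this oxygen from that of its selenium-bearing nitrile end. Going by these compounds, whether a methyl, a shorter carbon chain, or a chain ending in an amine or a carboxylic acid at this oxygen would hold the number of compound 3 stays open.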